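The compounds below may be only part of what the source reports. "The series", "measured", "known", "first", "only" and "open" are said of these compounds alone.

Measured so far in a functional assay on HEp-2 cells (Homo sapiens) for cytotoxicity, read by MTT assay, with a stated time of 72 h; on this read-out lower numbers stand for stronger inhibition and higher numbers for weaker inhibition:

Compound 1 `Cc1ccc2oc(CSc3nc4nc(C)cc(C)n4n3)cc(=O)c2c1` gives > 25000 nM, which is a limit of the assay and not a number.
Compound 2 `Cc1cc(C)n2nc(SCc3cc(=O)c4cc(Cl)ccc4o3)nc2n1` gives > 25000 nM, again a limit of the assay.
Compound 3 `Cc1ccc2oc(CSc3nnc(C)s3)cc(=O)c2c1` gives > 25000 nM, also a limit of the assay.

Compound 2 differs from compound 1 by one change, (chloro in place of methyl on an aromatic carbon). The step that the two limits leave unreadable from compound 1 to compound 2 cannot be sized because both values sit at the limit of > 25000 nM in this assay, at which 3 of the 3 values shown sit. Compound 3 carries a different core; how the core of compound 3 differs from the core of compound 1 is not broken down here.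

The compound still to be measured is compound 4 `Cc1nnc(SCc2cc(=O)c3cc(Cl)ccc3o2)s1`. For the measured compounds named here, it differs from compound 3 by chloro in place of methyl on an aromatic carbon, the same change as the one from compound 1 to compound 2, at the same place described in the same words.

Going by the values given here, for this assay the only information on this change is the unreadable step that the two limits leave unreadable from compound 1 to compound 2, where both ends sit at the limit. On that basis the step from compound 3 to compound 4 is expected to be small, at about a step that the limit leaves unreadable from compound 3 to compound 4, and the result is expected to remain at the limit rather than to become a readable number. Compound 4 is accordingly estimated at 40000 nM, with a range from 20000 nM to 120000 nM.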

Compound 4, half-maximal inhibitory concentration: > 25000 nM
Compound 4: a limit, no number; the forecaster's own chance of this, stated with the estimate: 85%; the middle value is on the limit's open side.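

In this assay compound 4 gives > 25000 nM, a limit of the assay and not a number. Neither the step from compound 3 to compound 4 nor the one from compound 1 to compound 2 can be read, because both ends of each pair sit at the same limit: the limit of > 25000 nM in this assay, at which 4 of the 4 values shown sit.

The compounds shown leave open what size or direction chloro in place of methyl on an aromatic carbon would have on a readable value in this assay.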